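A few compounds are considered here, and "the series" means these few. Any claim that something is new, unique, unknown or untested is made for them only; others in the source may bear on it.

Measured in an ADME assay on L6 cells (Rattus norvegicus) for cytotoxicity, read by resazurin assay, with a stated time of 72 h; a higher number here means a weaker inhibitor, a lower number a stronger inhibitor:
- compound 1 `OC(c1ccc(Cl)cc1)(c1cccnc1)c1cccc(F)c1` gives 66000 nM as its value
- compound 2 `COc1cccc(C(O)(c2ccc(Cl)cc2)c2cccnc2)c1` gives 85600 nM as its value

Compound 2 stands within the scatter of compound 1, so the two numbers do not separate. Compound 3 `CC(C)Oc1cccc(C(O)(c2ccc(Cl)cc2)c2cccnc2)c1` differs from compound 2 by isopropyl in place of methyl on an oxygen on an aromatic ring as isopropyl in place of methyl on an oxygen on an aromatic ring. For the measured compounds named here, the only measured step, a 1.3-fold higher number from compound 1 to compound 2 (0.11 log units; within the scatter) for methoxy in place of fluoro on an aromatic carbon, lay within the scatter. Going by the values given here, no measured step changes the group on that oxygen. No step beyond the scatter is therefore expected in this assay for this change. The expected step is a 1.2-fold lower number from compound 2 to compound 3 (0.09 log units; within the scatter) and remains an estimate. Compound 3 is estimated at 70000 nM with a range of 30000 nM to 130000 nM expected.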

Compound 3, half-maximal inhibitory concentration: 67600 nM
Compound 3: middle estimate off by 1.0-fold (0.02 log units), on the high side; low and high end bracket the measured number.
By their numbers in this assay, from the lowest: compounds 1, 3 and 2 (each within the scatter of the next).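

In this assay, the group on the oxygen on an aromatic ring now has a measured step: isopropyl in place of methyl gives a result within the scatter (a 1.3-fold lower number from compound 2 to compound 3 (0.10 log units; within the scatter)). Isopropoxy in place of fluoro on the aromatic carbon also stays within the scatter (a 1.0-fold higher number from compound 1 to compound 3 (0.01 log units; within the scatter)), so fluoro, methoxy and isopropoxy do not separate at this place. No supporting evidence bears on this result.

The compounds shown leave open whether a longer chain on the oxygen would give a step beyond the scatter. The same question stands for an amine or a carboxylic acid on the aromatic carbon.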